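A few compounds are considered here, and "the series" means these few. Any claim that something is new, unique, unknown or untested is made for them only; others in the source may bear on it.

Measured so far in a functional assay on CHO cells for agonist activity at Free fatty acid receptor 1 (Homo sapiens), read by a luciferase reporter, with a stated time of 24 h; a lower number here means that less compound is needed, a higher number that more compound is needed for the effect:
compound 1, `CC(C)c1ccccc1-c1cc2cc(CCC(=O)O)ccc2[nH]1`
compound 2, `O=C(O)CCc1ccc2[nH]c(-c3ccccc3F)cc2c1`

In this assay compound 1 gives only a limit, > 25 nM. Compound 2 gives 1210 nM, the one number shown in the set. The step that the limit leaves unreadable from compound 1 to compound 2 is therefore not readable, as noted in the limit of > 25 nM in this assay, at which 1 of the 2 values shown sits.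

Compound 3 is `COc1ccccc1-c1cc2cc(CCC(=O)O)ccc2[nH]1`; the change from compound 2 is methoxy in place of fluoro on an aromatic carbon. Going by the values given here, no measured step reads on this change, since the only comparison from compound 2 ends at a limit. The expected step of a 1.2-fold higher number from compound 2 to compound 3 (0.09 log units; within the scatter) is therefore set near zero, within the scatter. Compound 3 is estimated at 1500 nM, with a range from 400 nM to 6000 nM.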

Compound 3, half-maximal effective concentration: > 25 nM
Compound 3 ended at the assay's limit; the forecaster's own chance of this, stated with the estimate: 15%; the middle value lies beyond the limit too.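

No new step can be read from compound 3 to compound 1 or compound 2, as compound 3 gives only a limit: the limit of > 25 nM in this assay, at which 2 of the 3 values shown sit.
Going by these compounds, how methoxy or isopropyl compares numerically with fluoro on this aromatic carbon remains open.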